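Methyl to chloro on the compound 3 scaffold

This account rests on a few compounds, and the source may have more. Where it says the series, first, only, none or still open, it means among the compounds named here.

Values in a functional assay on A549 cells (Homo sapiens) for cytotoxicity; a lower number here means a stronger inhibitor, a higher number a weaker inhibitor:
- compound 1 `Cc1ccc(S(=O)(=O)N2C(=O)NCC2c2ccccc2)cc1`: > 316000 nM (a limit of the assay)
- compound 2 `O=C1NC(c2ccc(Br)cc2)CN1S(=O)(=O)c1ccc(Cl)cc1`: 161000 nM
- compound 3 `Cc1ccc(S(=O)(=O)N2C(=O)NCC2c2ccc(Br)cc2)cc1`: 67000 nM

Compound 1 is known only as a limit. Of the two actual numbers, compound 3 has the lower at 67000 nM, and the gap to compound 2 lies beyond the scatter.

The next compound to be measured is compound 4 `O=C1NCC(c2ccc(Br)cc2)N1S(=O)(=O)c1ccc(Cl)cc1`. It has chloro in place of methyl on an aromatic carbon, para to a large group, so 4-methylphenyl becomes 4-chlorophenyl (chloro in place of methyl on an aromatic carbon).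

Among the measured compounds shown here, no measured step covers this change. For the measured compounds named here, the one measured step is an at least 4.7-fold lower number from compound 1 to compound 3 (0.67 log units; beyond the scatter). That step is bromo in place of hydrogen on an aromatic carbon, and it starts from a limit, so it bears only loosely on the size expected here. Going by the values given here, the 4-chlorophenyl group also occurs in compound 2 at 161000 nM, but its core differs from that of compound 4, so no step links the two.

No step beyond the scatter is therefore expected in this assay, with a slight lean towards a higher number. The estimated step is a 1.1-fold higher number from compound 3 to compound 4 (0.05 log units; within the scatter). For compound 4 the expected value is 75000 nM, with an estimated range of 30000 nM to 180000 nM.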

Compound 4, half-maximal inhibitory concentration: 84000 nM
Compound 4: the middle estimate sits 1.1-fold (0.05 log units) below what was measured, within the range that was stated.
By their numbers in this assay, from the lowest: compounds 3, 4 and 2 (each within the scatter of the next, the first and the last beyond it). At a limit, above all of these: compound 1.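

In this assay, the change from 4-methylphenyl to 4-chlorophenyl on the shared core gives the first step read at this place: a 1.3-fold higher number from compound 3 to compound 4 (0.10 log units; within the scatter). Among the compounds shown here, at this aromatic carbon, para to a large group, the assay therefore does not separate chloro from methyl, whereas the earlier bromo step, an at least 4.7-fold lower number from compound 1 to compound 3 (0.67 log units; beyond the scatter), lies at a different place in the molecule, starts from a limit and is the only one of the two steps beyond the scatter. Nothing shown here gives a cause for the small size of the new step.

On these data alone, only methyl and chloro have been compared at this place, so how a methoxy group, an amine or a carboxylic acid there would read in this assay stays open. For the compounds shown here, also open is what the arrangement of the core contributes, since compound 2 and compound 4 carry the same 4-chlorophenyl group and the same bromo substituent on differing cores, and no step links that pair.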